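The source may hold more compounds than are shown below. What is called first, only, known or untested is meant among the compounds shown, and "the series" means these compounds.

Compound 1 `CC(C(=O)N1CCN(c2ccccc2F)CC1)N1C(=O)CCC1=O` sits second highest of the three numbers in a functional assay on the whole organism (strain Swiss) with Mus musculus as the target, in the maximal electroshock model, with a stated time of 2 h, at a dose of 300 mg/kg by the intraperitoneal route (on this read-out higher numbers stand for a stronger effect at the one dose given and lower numbers for a weaker effect), where compound 1 gives 25%. Compound 2 `CCC(C(=O)N1CCN(c2ccccc2F)CC1)N1C(=O)CCC1=O` gives 0% in this assay; the step of a number 25 percentage points lower from compound 1 to compound 2 (beyond the scatter) alters only the saturated chain and says nothing about the aromatic ring. For the measured compounds named here, compound 3 `CC(C(=O)N1CCN(c2ccccc2C(F)(F)F)CC1)N1C(=O)CCC1=O` gives 75% in this assay; the step of a number 50 percentage points higher from compound 1 to compound 3 (beyond the scatter) is the one measured change on that ring. Compound 4 `CC(C(=O)N1CCN(c2cccc(Cl)c2)CC1)N1C(=O)CCC1=O` differs from compound 1 on the same ring: 3-chlorophenyl in place of 2-fluorophenyl on an amine nitrogen in a ring. Only the ring step bears on this, and it was large upward, but neither chloro nor a 3-substituted ring has been measured, so the expected rise is set smaller, estimated as a number 20 percentage points higher from compound 1 to compound 4 (beyond the scatter). Compound 4 is expected to give 45% in this assay, within 15% to 80%.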

Compound 4, a percentage reported as activity, at one dose (the size of the read-out at that dose, not a potency): 50%
Compound 4: middle estimate off by 5 percentage points, on the low side; measured number inside the range.
By their numbers in this assay, from the lowest: compound 2; then compound 1; then compound 4; then compound 3.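

Compared with 2-fluorophenyl on the amine nitrogen in a ring, 3-chlorophenyl gives a number 25 percentage points higher from compound 1 to compound 4 (beyond the scatter) and so shows that a rise at this position in this assay does not depend on trifluoromethyl alone. For the compounds shown here, this change alters both the halogen and its place on the ring, and the single step cannot divide the rise between the two. No measured evidence here bears on the reason for the rise.

Still open, going by these compounds, is how 2-chlorophenyl and 3-fluorophenyl would compare, since that pair would separate halogen from place. Also open, on these data alone, is whether a methoxy group or a nitrile on this ring would hold the rise.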